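The compounds below may be only part of what the source reports. "The series", "measured", "known", "first", "only" and "open" are said of these compounds alone.

Compound 3 `N#Cc1cccc(-c2cnc(C(=O)CCCCCCc3ccccc3)o2)c1` gives the lowest number of the three measured in an assay (Rattus norvegicus) for inhibition of Fatty-acid amide hydrolase 1 (Homo sapiens) (a higher number here means a weaker inhibitor, a lower number a stronger inhibitor), at 15 nM; compound 2 `O=C(CCCCCCc1ccccc1)c1ncc(-c2cccc(O)c2)o1` gives 50 nM and compound 1 `N#Cc1ccccc1-c1cnc(C(=O)CCCCCCc2ccccc2)o1` gives 130 nM. Compound 4 `Nc1ccc(-c2cnc(C(=O)CCCCCCc3ccccc3)o2)cc1` differs from compound 3 by 4-aminophenyl in place of 3-cyanophenyl on an aromatic carbon. Going by the values given here, no measured step introduces an amino group or a 4-substituted phenyl. Among the compounds with values here, two steps bear loosely on it: an 8.7-fold lower number from compound 1 to compound 3 (0.94 log units; beyond the scatter) showed that relocating the nitrile on the phenyl shifts the number modestly, and a 3.3-fold lower number from compound 2 to compound 3 (0.52 log units; beyond the scatter) showed that a hydroxy in the nitrile's place gives a modestly higher number. A group carrying a hydrogen-bond donor is therefore expected to give a modestly higher number than compound 3, on the order of a 4.0-fold higher number from compound 3 to compound 4 (0.60 log units; beyond the scatter). Compound 4 is estimated at 60 nM, range 20 nM to 200 nM in this assay.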

Compound 4, inhibition constant: 90 nM
Compound 4: the middle estimate sits 1.5-fold (0.18 log units) below what was measured, and the stated range covers the measured number.
By their numbers in this assay, from the lowest: compound 3; then compounds 2, 4 and 1 (each within the scatter of the next, the first and the last beyond it).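

With a 6.0-fold higher number from compound 3 to compound 4 (0.78 log units; beyond the scatter) in this assay the 4-aminophenyl group falls short of 3-cyanophenyl at this position on the shared core. Against 3-hydroxyphenyl, a 1.8-fold higher number from compound 2 to compound 4 (0.26 log units; within the scatter) leaves the two groups unseparated, and against 2-cyanophenyl, a 1.4-fold lower number from compound 1 to compound 4 (0.16 log units; within the scatter) does the same, so 3-cyanophenyl alone stands apart from the other three groups. No evidence on the cause of these steps is at hand. Open, going by these compounds, is how a carboxylic acid, a methoxy or an amide on the phenyl would compare with the nitrile, and whether the amine and the nitrile keep this gap when each sits where the other sits now.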